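Methoxy addition on the benzyl ring of two cores

A few compounds are considered here, and "the series" means these few. Any claim that something is new, unique, unknown or untested is made for them only; others in the source may bear on it.

For the measured compounds named here, in a functional assay on SH-SY5Y cells (Homo sapiens) for antiproliferative activity, read by MTT assay, with a stated time of 48 h (on this read-out higher numbers stand for weaker inhibition of growth and lower numbers for stronger inhibition of growth), compound 3 `COc1cc(Cn2cnc3c(Cl)nc(Cl)nc32)cc(OC)c1` gives 1700 nM, the only number in the set so far. Compound 1 `COc1ccc(Cn2cnc3c(Cl)ncnc32)cc1OC` reaches only the limit of the assay, > 100000 nM. Compound 2 `COc1cc(Cn2cnc3c(Cl)ncnc32)cc(OC)c1OC` likewise stops at the limit, > 100000 nM. The step from compound 1 to compound 2, (methoxy in place of hydrogen on an aromatic carbon), is therefore a step that the two limits leave unreadable from compound 1 to compound 2; the limit of > 100000 nM in this assay, at which 2 of the 3 values shown sit, keeps its size hidden. The difference between the core of compound 1 and the core of compound 3 is not broken down here. Compound 4 `COc1cc(Cn2cnc3c(Cl)nc(Cl)nc32)cc(OC)c1OC` carries the same kind of change on the core of compound 3: methoxy in place of hydrogen on an aromatic carbon. The surroundings differ: in compound 3 the site is ortho to two methoxy groups and para to a large group, whereas in compound 1 it is ortho to a methoxy group, meta to a large group and meta to a methoxy group. Going by the values given here, with the only measured instance of this change unreadable, only a small step is expected, a 1.5-fold higher number from compound 3 to compound 4 (0.17 log units; within the scatter). In this assay compound 4 is estimated at 2500 nM, between 800 nM and 8000 nM.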

Compound 4, concentration for 50% growth inhibition: 9600 nM
For compound 4 the middle estimate is 3.8-fold (0.58 log units) below the measured one; the whole stated range lies below it.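

In this assay, methoxy in place of hydrogen on an aromatic carbon gives a 5.6-fold higher number from compound 3 to compound 4 (0.75 log units; beyond the scatter), so on the core of compound 3 this change gives a weaker growth inhibition of readable size. As far as these compounds go, the same change on the core of compound 1 cannot be read, so one sized instance stands alone, and whether the change carries across the two cores stays unknown because both compounds on that core sit at a limit: the limit of > 100000 nM in this assay, at which 2 of the 4 values shown sit. Chloro in place of hydrogen on an aromatic carbon gives an at least 10-fold lower number from compound 2 to compound 4 (1.01 log units; beyond the scatter), and the size of this step rests on a limit.

Open, from the compounds shown here alone, is how an amine or a carboxylic acid at the same aromatic carbon would compare with methoxy. Also open, going by these compounds, is whether a longer chain in place of methoxy would follow the step seen on the core of compound 3.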